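Swapping the hydroxy-methyl-pyrimidinyl arm for a pyridinyl

This account rests on a few compounds, and the source may have more. Where it says the series, first, only, none or still open, it means among the compounds named here.

Compound 2 `Cc1cc(O)nc(C[S+]([O-])C(c2ccccc2)c2ccccc2)n1` gives the highest number of the three measured in an assay on HEK293 cells for inhibition of sodium-dependent dopamine transporter (Homo sapiens), read by scintillation counting, with stated times of 5 min and 1 min (a lower number here means a stronger inhibitor, a higher number a weaker inhibitor), at 109000 nM. Its nearest neighbour is compound 3 `[O-][S+](Cc1nc(O)cc(C(F)(F)F)n1)C(c1ccccc1)c1ccccc1`, which in this assay gives 40400 nM; compound 1 `[O-][S+](Cc1cccs1)C(c1ccc(Cl)cc1)c1ccc(Cl)cc1`, in this assay, gives 7200 nM. Compound 4 `[O-][S+](Cc1ccncc1)C(c1ccccc1)c1ccccc1` differs from compound 2 by pyridin-4-yl in place of 4-hydroxy-6-methylpyrimidin-2-yl on a saturated chain carbon bound to a sulfur. Among the measured compounds shown here, the only single-change step known is a 2.7-fold lower number from compound 2 to compound 3 (0.43 log units; beyond the scatter), which alters a different part of that arm, so no measured step directly matches this change. For the measured compounds named here, compound 1 differs from compound 2 in more than one place and sets no step either. Compound 4 is therefore expected to show a modest improvement, a 3.1-fold lower number from compound 2 to compound 4 (0.49 log units; beyond the scatter), with wide uncertainty. The estimate for compound 4 in this assay is 35000 nM, within 9000 nM to 130000 nM.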

Compound 4, half-maximal inhibitory concentration: 63500 nM
The estimate for compound 4 lay 1.8-fold (0.26 log units) below the measured number; measured number inside the range.
By their numbers in this assay, from the lowest: compound 1; then compounds 3, 4 and 2 (each within the scatter of the next, the first and the last beyond it).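

In this assay, among the compounds shown here, the exchange of 4-hydroxy-6-methylpyrimidin-2-yl for pyridin-4-yl on a saturated chain carbon bound to a sulfur gives a 1.7-fold lower number from compound 2 to compound 4 (0.23 log units; within the scatter), the first reading of a change of the whole arm rather than of one substituent on it. For this pair, the arm can lose its hydrogen-bond donor with no change beyond the scatter. Nothing available explains this result. Left open is whether an amine or a carboxylic acid at this place would move the number beyond the scatter, and whether pyridin-4-yl behaves the same way on the core of compound 1.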